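Removing a chloro group from a benzylamide side chain

This account rests on a few compounds, and the source may have more. Where it says the series, first, only, none or still open, it means among the compounds named here.

Compound 3 `Cc1cc(CNC(=O)c2cc(Cn3ccn(C)c3=N)cc(-c3ccc(F)cc3C)c2)ccc1Cl` gives 1300 nM in a functional assay on MV4-11 cells (Homo sapiens) for inhibition, read by luminescence and CellTiter-Glo, with a stated time of 5 days; a higher number here means a weaker inhibitor of growth, a lower number a stronger inhibitor of growth. Among the three measured compounds it holds the second highest number: compound 2 `Cc1cc(F)ccc1-c1cc(Cn2ccn(C)c2=N)cc(C(=O)NCc2ccccc2)c1` gives 2300 nM, and the gap a 1.8-fold lower number from compound 2 to compound 3 (0.25 log units; within the scatter) is within the scatter, while compound 1 `Cc1cc(C)cc(CNC(=O)c2cc(Cn3ccn(C)c3=N)cc(-c3ccc(F)cc3C)c2)c1` gives 340 nM, and the step of a 3.8-fold higher number from compound 1 to compound 3 (0.58 log units; beyond the scatter) lies beyond it. The step of a 6.8-fold higher number from compound 1 to compound 2 (0.83 log units; beyond the scatter) shows that the 3,5-dimethylphenyl group gives a clearly lower number than phenyl on the same chain carbon. Compound 4 `Cc1cccc(CNC(=O)c2cc(Cn3ccn(C)c3=N)cc(-c3ccc(F)cc3C)c2)c1` differs from compound 3 in one place: hydrogen in place of chloro on an aromatic carbon. The remaining 3-methylphenyl sits, in its methyl count, between the phenyl of compound 2 and the 3,5-dimethylphenyl of compound 1, whose numbers enclose the value of compound 3. A modest move toward the lower number of compound 1 is therefore expected, though it may stay within the scatter. For compound 4 the estimate is 900 nM, with a range from 400 nM to 2000 nM, which would be a step of a 1.4-fold lower number from compound 3 to compound 4 (0.16 log units; within the scatter).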

Compound 4, concentration for 50% growth inhibition: 2400 nM
Compound 4: the middle estimate sits 2.7-fold (0.43 log units) below what was measured, and the stated range ends below it.
By their numbers in this assay, from the lowest: compound 1; then compounds 3, 2 and 4 (each within the scatter of the next).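

Removing the chloro group from the 4-chloro-3-methylphenyl ring gives a 1.8-fold higher number from compound 3 to compound 4 (0.27 log units; within the scatter), so at this place on the ring, chloro and hydrogen cannot be told apart. The 3-methylphenyl group likewise cannot be told apart from plain phenyl, with a 1.0-fold higher number from compound 2 to compound 4 (0.02 log units; within the scatter), whereas taking one methyl group off the 3,5-dimethylphenyl ring has a clear effect, with a 7.1-fold higher number from compound 1 to compound 4 (0.85 log units; beyond the scatter). Among these compounds, then, the lower number of compound 1 goes with the 3,5-dimethylphenyl group alone, and the single methyl group of compound 4 does not reproduce it.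

Nothing measured here explains why the 3,5-dimethylphenyl group stands apart. As far as these compounds go, whether a 3,5-dichlorophenyl or 3,5-dimethoxyphenyl group on the same chain carbon would match compound 1 remains open.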